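Replacing the ring-bearing group of compound 3

This account rests on a few compounds, and the source may have more. Where it says the series, first, only, none or still open, it means among the compounds named here.

In a functional assay (aorta) with Rattus norvegicus as the target (on this read-out higher numbers stand for an effect only at larger amounts of compound and lower numbers for an effect already at smaller amounts), compound 1 (`CNC(=N)Nc1nc(-c2ccc(OC)cc2)c(-c2ccc(OC)cc2)s1`) stands at 1.2 uM and compound 2 (`COc1ccc(-c2nc(/N=C(\N)NC(C)C)sc2-c2ccc(OC)cc2)cc1`) at 9.1 uM while compound 3 (`COc1ccc(-c2nc(/N=C(\N)[N+]3(C)CCCCC3)sc2-c2ccc(OC)cc2)cc1`) reaches 21 uM and so holds the highest of the three numbers. Across these three compounds the number climbs as the group grows: the steps are a 7.6-fold higher number from compound 1 to compound 2 (0.88 log units; beyond the scatter) and then a 2.3-fold higher number from compound 2 to compound 3 (0.36 log units; beyond the scatter) for a total of an 18-fold higher number from compound 1 to compound 3 (1.24 log units; beyond the scatter) in all. Compound 4 (`COc1ccc(-c2nc(CNC(C)=O)sc2-c2ccc(OC)cc2)cc1`) differs from compound 3 by a group of 5 heavy atoms (3 carbon, 1 nitrogen, 1 oxygen; no ring) in place of a group of 10 heavy atoms (7 carbon, 3 nitrogen; one six-membered non-aromatic ring with 1 hetero atom), on an aromatic carbon and the incoming group is acetamidomethyl. Among the measured compounds shown here, no measured step introduces a group of this kind, so the size trend is only a loose guide. Still, the incoming group is the smaller one, and the step of an 18-fold higher number from compound 1 to compound 3 (1.24 log units; beyond the scatter) links the smaller group to the lower number. In this assay the expected change is a 2.6-fold lower number from compound 3 to compound 4 (0.42 log units; beyond the scatter) as a modest move toward a lower number. Compound 4 is expected at 8 uM with an estimated range from 1.5 uM to 40 uM on this reading.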

Compound 4, concentration for half-maximal effect: 8.1 uM
For compound 4 the middle estimate is 1.0-fold (0.01 log units) below the measured one, and the stated range covers the measured number.
By their numbers in this assay, from the lowest: compound 1; then compounds 4 and 2 (each within the scatter of the next); then compound 3.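

Acetamidomethyl carries no net charge and no ring, yet in this assay it gives a 2.6-fold lower number from compound 3 to compound 4 (0.41 log units; beyond the scatter), and a 1.1-fold lower number from compound 2 to compound 4 (0.05 log units; within the scatter), so this position on the ring does not need the three nitrogens of the earlier groups to reach the range of compound 2. Heavy-atom count alone does not set the number here: the outgoing and incoming groups are the same size in a 6.8-fold higher number from compound 1 to compound 4 (0.83 log units; beyond the scatter), and this pair goes against the earlier link between smaller groups and lower numbers. Nothing available here accounts for these differences.

Going by these compounds, whether a plain aminomethyl group or a carboxylic acid at this position would behave like acetamidomethyl remains open. So does the effect of a longer chain on the amide carbonyl.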